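Phenyl for thiophen-2-yl in a series at its limit

This account rests on a few compounds, and the source may have more. Where it says the series, first, only, none or still open, it means among the compounds named here.

In a functional assay on CCRF-CEM cells (Homo sapiens), read by MTT assay, with a stated time of 72 h (on this read-out higher numbers stand for weaker inhibition and lower numbers for stronger inhibition), compound 3 (`CNc1ncnc2c1c(-c1cccs1)cn2[C@@H]1O[C@H](CO)[C@@H](O)[C@H]1O`) gives > 20000 nM as a limit and not a number. Compound 2 (`CNc1ncnc2c1c(-c1ccoc1)cn2[C@@H]1O[C@H](CO)[C@@H](O)[C@H]1O`) gives > 20000 nM as a limit too. Compound 1 (`CSc1ncnc2c1c(-c1ccccc1)cn2[C@@H]1O[C@H](CO)[C@@H](O)[C@H]1O`), which also carries phenyl, gives > 20000 nM as a limit too. Every reading so far thus stands at the limit of > 20000 nM in this assay, at which 3 of the 3 values shown sit, and none is a number.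

Compound 4 (`CNc1ncnc2c1c(-c1ccccc1)cn2[C@@H]1O[C@H](CO)[C@@H](O)[C@H]1O`) has phenyl in place of thiophen-2-yl on an aromatic carbon. Among the compounds with values here, the one measured step bearing on this is a step that the two limits leave unreadable from compound 2 to compound 3 and it gives no size to carry over. No readable change is expected in this assay and no direction can be given. The step expected is a step that the limit leaves unreadable from compound 3 to compound 4 and it may well stay unreadable. The estimate for compound 4 is 30000 nM with an expected range from 12000 nM to 80000 nM and a report at the limit is the likeliest outcome.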

Compound 4, half-maximal inhibitory concentration: > 20000 nM
Compound 4 gave a limit, no number; the forecaster's own chance of this, stated with the estimate: 85%; the middle value lies beyond the limit too.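

No step can be read between compound 4 and compound 1, compound 2 or compound 3 in this assay, since all four readings are limits and not numbers: the limit of > 20000 nM in this assay, at which 4 of the 4 values shown sit.

The compounds shown leave open how large any of these changes is, and whether any group here gives a measurable value.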